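A few compounds are considered here, and "the series" means these few. Any claim that something is new, unique, unknown or untested is made for them only; others in the source may bear on it.

In a functional assay on A549 cells (Homo sapiens) for antiproliferative activity, read by MTT assay, with a stated time of 72 h (on this read-out higher numbers stand for weaker inhibition and lower numbers for stronger inhibition), compound 1 `S=C(Sc1ccccc1)N1CCCCC1` gives 7930 nM and compound 2 `CCCCN(CCCC)C(=S)Sc1ccccc1` gives 9760 nM with no difference between the two beyond the scatter. Compound 3 `Cc1ccc(SC(=S)N2CCN(C(=O)OC(C)(C)C)CC2)cc1` stands lowest of the three at 2110 nM and so shows the strongest inhibition, with the numbers of both other compounds higher by more than the scatter. Compound 4 `COc1ccc(SC(=S)N2CCN(C(=O)OC(C)(C)C)CC2)cc1` has not yet been measured. It differs from compound 3 in one place only. The counted difference methoxy in place of methyl on an aromatic carbon is methoxy in place of methyl on an aromatic carbon, para to a large group, which also reads as 4-methylphenyl to 4-methoxyphenyl.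

For the measured compounds named here, no two measured compounds differ in a single place, so the data give no direct guide to this step. Compounds 1 and 2 differ from compound 3 in several places at once, and their gaps to it cannot be assigned to any one group. For an exchange this small, no shift beyond the scatter is expected in this assay and neither direction is favoured. The expectation therefore starts from compound 3 at 2110 nM and stays close to it. The estimated step of a 1.1-fold higher number from compound 3 to compound 4 (0.06 log units; within the scatter) is expected to stay within the scatter. Compound 4 is expected at 2400 nM with an estimated range from 1100 nM to 5200 nM once it is measured.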

Compound 4, half-maximal inhibitory concentration: 712 nM
Compound 4: the middle estimate sits 3.4-fold (0.53 log units) above what was measured, outside the stated range (below it).
By their numbers in this assay, from the lowest: compound 4; then compound 3; then compounds 1 and 2 (each within the scatter of the next).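

In this assay, for the compounds shown here, the exchange of methyl for methoxy on an aromatic carbon, para to a large group, gives a 3.0-fold lower number from compound 3 to compound 4 (0.47 log units; beyond the scatter) and is the first change in this set that can be read at a single place. It shows that this position is not indifferent to what it carries: going from 4-methylphenyl to 4-methoxyphenyl, which adds one oxygen and one hydrogen-bond acceptor to the count, moves the result beyond the scatter towards stronger inhibition. No evidence at hand bears on why this step occurs.

With only two groups compared at this position, the compounds shown leave open whether the oxygen itself matters or any larger group would do, which a hydroxyl, an ethoxy, a fluorine or a dimethylamino group in the same place could help separate. They also leave open whether the same exchange would bring a similar step on the core of compound 1 or of compound 2, where the aromatic ring carries neither methyl nor methoxy.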